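Aryl urea series: bromo to trifluoromethyl on the aryl

A few compounds are considered here, and "the series" means these few. Any claim that something is new, unique, unknown or untested is made for them only; others in the source may bear on it.

The series shares one core; compound 1 `COc1cccc(-n2cc(COc3cccc(NC(=O)Nc4ccc(Cl)c(C(F)(F)F)c4)c3)nn2)c1`, compound 2 `CCc1ccc(-n2cc(COc3cccc(NC(=O)Nc4ccc(Cl)c(C(F)(F)F)c4)c3)nn2)cc1` and compound 3 `O=C(Nc1cccc(OCc2cn(-c3ccc(Br)cc3)nn2)c1)Nc1ccc(Cl)c(C(F)(F)F)c1` differ only in the aryl group on the aromatic nitrogen. In a functional assay on HepG2 cells (Homo sapiens) for inhibition, read by MTT assay, with a stated time of 72 h (a lower number here means a stronger inhibitor, a higher number a weaker inhibitor), compound 1 gives 1310 nM, compound 2 gives 1950 nM and compound 3 gives 2730 nM. Compound 3 holds the highest of the three numbers: a 1.4-fold higher number from compound 2 to compound 3 (0.15 log units; within the scatter), whereas a 2.1-fold higher number from compound 1 to compound 3 (0.32 log units; beyond the scatter). Compound 4 `O=C(Nc1cccc(OCc2cn(-c3ccc(C(F)(F)F)cc3)nn2)c1)Nc1ccc(Cl)c(C(F)(F)F)c1` carries trifluoromethyl in place of bromo on an aromatic carbon. Among the measured compounds shown here, no measured step exchanges bromo for trifluoromethyl; the step that bears most closely is a 1.4-fold higher number from compound 2 to compound 3 (0.15 log units; within the scatter), and a 1.5-fold higher number from compound 1 to compound 2 (0.17 log units; within the scatter) also shows that swaps of this aryl substituent stay small. Compound 4 is therefore expected to show a 1.1-fold higher number from compound 3 to compound 4 (0.04 log units; within the scatter), not beyond the scatter. The estimate for compound 4 is 3000 nM, with a range of 1400 nM to 6500 nM.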

Compound 4, half-maximal inhibitory concentration: 1800 nM
Beside the measured number, compound 4's estimate is 1.7-fold (0.22 log units) above it; the measured number falls inside the stated range.
By their numbers in this assay, from the lowest: compounds 1, 4, 2 and 3 (each within the scatter of the next, the first and the last beyond it).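

Trifluoromethyl on this aromatic carbon stays within the scatter of all three earlier compounds in this assay, with a 1.5-fold lower number from compound 3 to compound 4 (0.18 log units; within the scatter) and a 1.1-fold lower number from compound 2 to compound 4 (0.03 log units; within the scatter) and a 1.4-fold higher number from compound 1 to compound 4 (0.14 log units; within the scatter). Bromo, ethyl and trifluoromethyl at this position are therefore not separated by this assay, even though trifluoromethyl brings more heavy atoms than bromo. Nothing at hand explains these small steps. On these data alone, whether an amine or a carboxylic acid at this position would move the number beyond the scatter remains open.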